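Substituent swaps on the thiazole aryl of a pyrazoline series

A few compounds are considered here, and "the series" means these few. Any claim that something is new, unique, unknown or untested is made for them only; others in the source may bear on it.

Measured compounds:
compound 1, `Fc1ccc(C2CC(c3ccc(Cl)s3)=NN2c2nc(-c3ccc(Br)cc3)cs2)cc1` — in a functional assay on A549 cells (Homo sapiens) for antiproliferative activity, read by XTT assay, with a stated time of 24 h (on this read-out higher numbers stand for weaker inhibition and lower numbers for stronger inhibition), compound 1 gives 62.5 ug/mL.
compound 2, `CS(=O)(=O)c1ccc(-c2csc(N3N=C(c4ccc(Cl)s4)CC3c3ccc(F)cc3)n2)cc1` — in this assay compound 2 gives only the limit > 500 ug/mL.
compound 3, `Fc1ccc(-c2csc(N3N=C(c4ccc(Cl)s4)CC3c3ccc(F)cc3)n2)cc1` — in this assay compound 3 gives only the limit > 500 ug/mL.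

Where compound 3 stands: in this assay compound 3 sits at the limit, so no number is known for it, only that it lies beyond what the assay reports; (the limit of > 500 ug/mL in this assay, at which 2 of the 3 values shown sit).

The change to compound 4, `O=[N+]([O-])c1ccc(-c2csc(N3N=C(c4ccc(Cl)s4)CC3c3ccc(F)cc3)n2)cc1`, is nitro in place of fluoro on an aromatic carbon.

Steps that bear on it: an at least 8.0-fold higher number from compound 1 to compound 3 (0.90 log units; beyond the scatter) and an at least 8.0-fold higher number from compound 1 to compound 2 (0.90 log units; beyond the scatter) both run from a readable number into the limit, so the aryl substituent on this ring is shown to move the read-out by at least a modest amount. Among the measured compounds shown here, the closest pair, a step that the two limits leave unreadable from compound 2 to compound 3, gives no size, and no measured step exchanges fluoro for nitro. With compound 3 already at the limit, the most likely outcome is that compound 4 also gives no number, and an at least 1.2-fold lower number from compound 3 to compound 4 (0.09 log units; that floor lies within the scatter) is expected to be small or unreadable.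

Estimate: compound 4 is expected to give about 400 ug/mL in this assay, with a range from 120 ug/mL to 1000 ug/mL.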

Compound 4, half-maximal inhibitory concentration: > 500 ug/mL
Compound 4: no number, only a limit; the forecaster's own chance of this, stated with the estimate: 65%; at least 1.2-fold (0.09 log units) between middle value and limit.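

In this assay, nitro joins methylsulfonyl and fluoro at the limit on this aryl ring, which leaves bromo, in compound 1, as the only one of the four substituents shown with a readable number: the limit of > 500 ug/mL in this assay, at which 3 of the 4 values shown sit.

Replacing bromo with nitro gives an at least 8.0-fold higher number from compound 1 to compound 4 (0.90 log units; beyond the scatter), the same floor as the two earlier replacements, and that floor is set by the limit and is not a measured gap. The steps among compound 2, compound 3 and compound 4 join limit to limit and cannot be read, so these three compounds cannot be placed in any order.

On these data alone, how far each of these three compounds lies beyond the limit remains open, as does whether the readable result of compound 1 is specific to bromo. Chloro, iodo, methyl, methoxy or an amine at the same place on the aryl ring would show whether a readable number extends beyond bromo or stays confined to compound 1.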